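Swapping bromo for chloro on a cytotoxic acrylamide series

A few compounds are considered here, and "the series" means these few. Any claim that something is new, unique, unknown or untested is made for them only; others in the source may bear on it.

Three compounds that share one core and differ only in the aryl group attached to an aromatic nitrogen have been tested in an ADME assay on HT-29 cells (Homo sapiens) for cytotoxicity, read by MTT assay, with a stated time of 72 h; a higher number here means a weaker inhibitor, a lower number a stronger inhibitor. Compound 1 `C=CC(=O)Nc1cc(Nc2ncc3ncn(-c4ccccc4Cl)c3n2)c(OC)cc1N(C)CCN(C)C` gives 11300 nM in this assay. Compound 2 `C=CC(=O)Nc1cc(Nc2ncc3ncn(-c4ccccc4Br)c3n2)c(OC)cc1N(C)CCN(C)C` gives 16200 nM. Compound 3 `C=CC(=O)Nc1cc(Nc2ncc3ncn(-c4ccc(F)c(Br)c4)c3n2)c(OC)cc1N(C)CCN(C)C` gives 3640 nM. Compound 2 and compound 1 differ by chloro in place of bromo on an aromatic carbon, and this step gives a 1.4-fold lower number from compound 2 to compound 1 (0.16 log units; within the scatter). Compound 2 and compound 3 differ by 3-bromo-4-fluorophenyl in place of 2-bromophenyl on an aromatic nitrogen, a change of the whole aryl group, and the step gives a 4.5-fold lower number from compound 2 to compound 3 (0.65 log units; beyond the scatter); the related step of a 3.1-fold lower number from compound 1 to compound 3 (0.49 log units; beyond the scatter) points the same way. Compound 3 thus sits lowest of the three in this assay.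

Compound 4 `C=CC(=O)Nc1cc(Nc2ncc3ncn(-c4ccc(F)c(Cl)c4)c3n2)c(OC)cc1N(C)CCN(C)C` has not yet been measured. It differs from compound 3 by chloro in place of bromo on an aromatic carbon. Within the data shown here, this is the same kind of change as the one from compound 2 to compound 1, though not the same: there the chloro stood ortho to a large group, here it stands ortho to a fluoro group and meta to a large group. The earlier swap moved the number only within the scatter, so compound 4 is expected to land near compound 3, with an estimated step of a 1.2-fold lower number from compound 3 to compound 4 (0.08 log units; within the scatter) in this assay, resting on the step of a 1.4-fold lower number from compound 2 to compound 1 (0.16 log units; within the scatter). The estimate for compound 4 in this assay is 3000 nM, expected between 1500 nM and 7000 nM.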

Compound 4, half-maximal inhibitory concentration: 1610 nM
The estimate for compound 4 lay 1.9-fold (0.27 log units) above the measured number; the measured number falls inside the stated range.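

In this assay, chloro in place of bromo on the 3-bromo-4-fluorophenyl group gives a 2.3-fold lower number from compound 3 to compound 4 (0.35 log units; beyond the scatter), while changing the whole aryl group gives a 10-fold lower number from compound 2 to compound 4 (1.00 log units; beyond the scatter) and a 7.0-fold lower number from compound 1 to compound 4 (0.85 log units; beyond the scatter). Set beside the earlier swap, the same change points the same way on both aryl groups, and the two steps cannot be told apart in size: the same change on two cores in this assay, a 1.4-fold lower number (0.16 log units; within the scatter) from compound 2 to compound 1 and a 2.3-fold lower number (0.35 log units; beyond the scatter) from compound 3 to compound 4, 1.6-fold (0.20 log units) apart, within the scatter of two such steps Only the second step lies beyond the scatter, so within these four compounds the swap carries over in direction, but two pairs cannot show that it would do the same on any other aryl group, nor why the number moves.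

On these data alone, what a methyl, a nitrile or an amine would do in place of the chloro of compound 4 stays open, so these compounds cannot say whether a halogen is needed there at all. As far as these compounds go, it is equally open whether the numbers would hold with a plain propanamide in place of the acrylamide, which all four compounds share.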